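The compounds below may be only part of what the source reports. "The series", "measured", "known", "first", "only" and "open" are said of these compounds alone.

In an assay on isolated protein for inhibition of DNA topoisomerase 1 (Homo sapiens), with a stated time of 30 min, tested at 100 uM (on this read-out lower numbers stand for less inhibition and higher numbers for more inhibition at the one concentration tested (going by the name of the read-out)), compound 3 `Oc1ccc(-c2cc(-c3ccc(O)cc3)nc(-c3ccccc3O)c2)cc1` gives 0%. Compound 1 `Oc1ccc(-c2cc(-c3ccccc3O)cc(-c3ccccc3O)n2)cc1` gives 0.3% and compound 2 `Oc1ccc(-c2cc(-c3cccc(O)c3)nc(-c3ccccc3O)c2)cc1` gives 1.5%; all three numbers lie within the scatter of one another, so compound 3 stands apart from neither. Compound 4 `Oc1ccc(-c2cc(-c3ccccc3O)nc(-c3ccccc3O)c2)cc1` differs from compound 3 in one place: 2-hydroxyphenyl in place of 4-hydroxyphenyl on an aromatic carbon. The nearest guide is the reverse exchange, a number 0.3 percentage points lower from compound 1 to compound 3 (within the scatter), which is within the scatter; the related exchange a number 1.5 percentage points lower from compound 2 to compound 3 (within the scatter) is likewise within the scatter. Nothing in the series therefore points to a step beyond the scatter for 2-hydroxyphenyl in place of 4-hydroxyphenyl on an aromatic carbon, in either direction. Compound 4 is expected to give 0.5% (range 0% to 5%), an expected step of a number 0.5 percentage points higher from compound 3 to compound 4 (within the scatter) that is essentially nil.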

Compound 4, a percentage reported as inhibition, at one concentration (the size of the read-out at that concentration, not a potency): 3.7%
For compound 4 the middle estimate is 3.2 percentage points below the measured one; the range from low to high includes it.
By their numbers in this assay, from the lowest: compounds 3, 1, 2 and 4 (each within the scatter of the next).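

In this assay moving the hydroxyl on the aromatic carbon next to the ring nitrogen gives a number 3.7 percentage points higher from compound 3 to compound 4 (within the scatter) and also a number 2.2 percentage points higher from compound 2 to compound 4 (within the scatter) with 2-hydroxyphenyl entering. All three hydroxyphenyl forms at this position therefore read alike, and 2-hydroxyphenyl here adds no step beyond the scatter. No evidence is available on what lies behind these small numbers. Still open, going by these compounds, is whether an amine or a carboxylic acid in place of the hydroxyl at this position would move the number beyond the scatter. The same question stands for a methoxy group.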